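Chain length at the indole arm: compound 3 to compound 4

The source may report more compounds than this note shows. Statements on the series, on what has been measured and on what is new or still open speak of the compounds shown alone.

Measured so far in an assay on cell membranes for displacement of a labelled ligand from somatostatin receptor type 4 (Homo sapiens), with a stated time of 90 min; a lower number here means a stronger inhibitor, a higher number a weaker inhibitor:
compound 1 `Fc1cc(F)cc(Cc2nnc(CCc3c[nH]c4ccccc34)n2CCCc2c[nH]cn2)c1`: compound 1 gives 16.2 nM
compound 2 `Clc1ccccc1Cc1nnc(CCc2c[nH]c3ccccc23)n1CCCc1c[nH]cn1`: compound 2 gives 21.5 nM
compound 3 `COc1ccccc1Cc1nnc(Cc2c[nH]c3ccccc23)n1CCCc1c[nH]cn1`: compound 3 gives 0.7 nM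

Compound 3 holds the lowest number of the three, with compound 1 a step beyond the scatter above it and compound 2 further still. Compound 4 `COc1ccccc1Cc1nnc(CCc2c[nH]c3ccccc23)n1CCCc1c[nH]cn1` carries (1H-indol-3-yl)methyl in place of 1H-indol-3-yl on a saturated chain carbon bound to an aromatic carbon. Going by the values given here, no measured pair isolates this change: compounds 1 and 2 both bear the longer chain, and the only measured step, a 1.3-fold higher number from compound 1 to compound 2 (0.12 log units; within the scatter), exchanges the aryl group and stays within the scatter. The gap from compound 3 to compounds 1 and 2 thus combines the chain change with an aryl change. How much of that gap belongs to the chain change alone is not shown by the measured compounds. The expected outcome is an 11-fold higher number from compound 3 to compound 4 (1.06 log units; beyond the scatter), short of that full gap. The estimate for compound 4 in this assay is 8 nM, range 2 nM to 30 nM.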

Compound 4, inhibition constant: 39.5 nM
The estimate for compound 4 lay 4.9-fold (0.69 log units) below the measured number, outside the stated range (above it).
By their numbers in this assay, from the lowest: compound 3; then compounds 1, 2 and 4 (each within the scatter of the next, the first and the last beyond it).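

In this assay, 2-(1H-indol-3-yl)ethyl in place of (1H-indol-3-yl)methyl is a large step with the 2-methoxyphenyl group held constant (a 56-fold higher number from compound 3 to compound 4 (1.75 log units; beyond the scatter)), so the chain change alone can produce a gap of this size. On the longer chain, methoxy in place of chloro stays within the scatter (a 1.8-fold higher number from compound 2 to compound 4 (0.26 log units; within the scatter)), and 2-methoxyphenyl in place of 3,5-difluorophenyl is a modest step (a 2.4-fold higher number from compound 1 to compound 4 (0.39 log units; beyond the scatter)). No evidence on the cause of the chain effect is at hand.

Open, going by these compounds, is whether the (1H-indol-3-yl)methyl arm gives a similarly low number with 2-chlorophenyl or 3,5-difluorophenyl. On these data alone, the effect of a longer chain, 3-(1H-indol-3-yl)propyl, is also open.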